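Thiophene positional swap on two nucleoside cores: cytotoxicity notes

A few compounds are considered here, and "the series" means these few. Any claim that something is new, unique, unknown or untested is made for them only; others in the source may bear on it.

Compound 1 `OC[C@H]1O[C@@H](n2cc(F)c3c(-c4cccs4)ncnc32)[C@H](O)[C@@H]1O` and compound 2 `OC[C@H]1O[C@@H](n2cc(F)c3c(-c4ccsc4)ncnc32)[C@H](O)[C@@H]1O` share one core and differ in a single place. In an ADME assay on MRC5 cells (Homo sapiens) for cytotoxicity, read by MTT assay, with a stated time of 72 h (a higher number here means that more compound is tolerated, a lower number that less compound is tolerated), compound 1 gives 47200 nM and compound 2 gives 50000 nM. The change from compound 1 to compound 2 is thiophen-3-yl in place of thiophen-2-yl on an aromatic carbon and it made a 1.1-fold higher number from compound 1 to compound 2 (0.03 log units; within the scatter), so the two numbers are not told apart.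

Compound 3 `CCCCCCCCCCCCCCCCCCOP(=O)(O)OC[C@H]1O[C@@H](n2ccc3c(-c4cccs4)ncnc32)[C@H](O)[C@@H]1O` has a different core; the difference between the core of compound 3 and the core of compound 1 is not broken down here. For compound 3 the entry in this assay reads "not determined" (no result reported), so no number is available for it. Compound 4 `CCCCCCCCCCCCCCCCCCOP(=O)(O)OC[C@H]1O[C@@H](n2ccc3c(-c4ccsc4)ncnc32)[C@H](O)[C@@H]1O` is made from compound 3 by thiophen-3-yl in place of thiophen-2-yl on an aromatic carbon, the same change as that from compound 1 to compound 2, on the same place.

In this assay the swap left the pair compound 1 and compound 2 within scatter, so from compound 3 to compound 4 a step of similar size is expected, resting on that single precedent and on nothing for the core of compound 3 itself. Compound 4 is therefore estimated at 20000 nM in this assay, between 4000 nM and 50000 nM.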

Compound 4, half-maximal cytotoxic concentration: > 50000 nM
Compound 4 ended at the assay's limit; the forecaster's own chance of this, stated with the estimate: 30%; middle value at least 2.5-fold (0.39 log units) away from the limit.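

In this assay compound 4 gives > 50000 nM, which is a limit of the assay and not a number. Among these compounds, compound 3 has no number there, so no step to compound 4 can be read. Open remains whether thiophen-3-yl in place of thiophen-2-yl acts on the core of compound 3 as it does on the core of compound 1.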